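Replacing the Ethylphenyl Arm: From Compound 1 to Compound 3

This account rests on a few compounds, and the source may have more. Where it says the series, first, only, none or still open, it means among the compounds named here.

Of the compounds shown here, two sharing a common core have been tested in a functional assay on HCC827 cells (Homo sapiens) for inhibition, read by MTT assay, with a stated time of 48 h, tested at 10 uM; on this read-out lower numbers stand for less inhibition and higher numbers for more inhibition at the one concentration tested (going by the name of the read-out). Compound 1, `CCc1cccc(Nc2cc(NC(=O)Nc3cc(OC)cc(OC)c3)ncn2)c1`, gives 52.6% in this assay, and compound 2, `Cc1ccc(Nc2cc(NC(=O)Nc3c(Cl)cccc3Cl)ncn2)cc1C`, gives 84.3%. Compound 1 therefore stands lowest of the two numbers shown, and compound 2 lies above it by a margin beyond the usual scatter of this kind of measurement. Compound 3, `COc1cc(NC(=O)Nc2cc(Nc3ccc(F)c(Cl)c3)ncn2)cc(OC)c1`, has not yet been measured in this assay. It differs from compound 1 at a single place: 3-chloro-4-fluorophenyl in place of 3-ethylphenyl on a nitrogen on an aromatic ring. Compound 2 and compound 3 differ from each other at more than one place, so the gap between the two measured values cannot be tied to any one change; the numbers show only that altering two parts of the molecule at once can move the read-out a long way. Going by the values given here, no measured pair isolates the present change, so the step of a number 9.4 percentage points higher from compound 1 to compound 3 (within the scatter) is expected to be a modest rise, near the edge of the scatter rather than clearly beyond it. For compound 3 the estimated inhibition is 62%, with a range from 40% to 82%.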

Compound 3, a percentage reported as inhibition, at one concentration (the size of the read-out at that concentration, not a potency): 53.1%
Beside the measured number, compound 3's estimate is 8.9 percentage points above it, within the range that was stated.
By their numbers in this assay, from the lowest: compounds 1 and 3 (each within the scatter of the next); then compound 2.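

In this assay, going by these compounds alone, putting 3-chloro-4-fluorophenyl in place of 3-ethylphenyl on the nitrogen on the aromatic ring gives a number 0.5 percentage points higher from compound 1 to compound 3 (within the scatter), the first step that isolates a single place, and it does not separate the two compounds. The groups that leave and enter have the same count of heavy atoms and the same six-membered aromatic ring of carbon only, and on this read-out an ethyl group and a pair of halogens on that ring cannot be told apart while the rest of compound 1 stays as it is. Nothing in the available data bears on why the two groups read alike.

The compounds shown leave open whether this position responds at all, since an aryl group carrying an amine or a carboxylic acid, or a longer chain such as butyl in place of the ethyl group, could read quite differently from these two. Within the data shown here, they also leave open whether the same exchange would again make no clear difference with another group on the far side of the urea, such as the one in compound 2.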